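Bromo Added to Compound 2: An Expected Gain

A few compounds are considered here, and "the series" means these few. Any claim that something is new, unique, unknown or untested is made for them only; others in the source may bear on it.

Of the compounds shown here, three built on one shared core have been tested in an assay for inhibition of Indoleamine 2,3-dioxygenase 1 (Homo sapiens), with stated times of 10 min and 60 min, tested at 10 uM; on this read-out higher numbers stand for a stronger effect at the one concentration tested and lower numbers for a weaker effect. Compound 1 `Oc1ccc(CNc2cc(C(F)(F)F)cc3[nH]ncc23)c(Cl)c1` gives 83% in this assay. Compound 2 `O=[N+]([O-])c1ccccc1CNc1cccc2[nH]ncc12` gives 25%, and compound 3 `O=C(O)c1cccc(CNc2cc(C(F)(F)F)cc3[nH]ncc23)c1` gives 11%. Among these three numbers compound 2 stands second highest: its nearest neighbour is compound 3, whose number lies lower by more than the usual scatter, while compound 1 lies far higher, again beyond the scatter. No two of these measured compounds differ in just one place, so no single structural step can be read directly from them.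

Compound 4 `O=[N+]([O-])c1ccccc1CNc1cc(Br)cc2[nH]ncc12` has not yet been measured. It differs from compound 2 by bromo in place of hydrogen on an aromatic carbon. Within the data shown here, no measured pair shows this exact change, so its effect is uncertain. The step from compound 2 to compound 4 in this assay is nonetheless expected to be a moderate rise, a number 20 percentage points higher from compound 2 to compound 4 (beyond the scatter), partly because compound 1, which also carries a group on its core, gives 83%. Compound 4 is therefore expected to give about 45%, within a range from 20% to 70%.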

Compound 4, a percentage reported as inhibition, at one concentration (the size of the read-out at that concentration, not a potency): 67%
Estimate against measurement, compound 4: 22 percentage points below; low and high end bracket the measured number.
By their numbers in this assay, from the lowest: compound 3; then compound 2; then compound 4; then compound 1.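

Placing bromo on this aromatic carbon, para to a fused ring and meta to a large group, gives in this assay a number 42 percentage points higher from compound 2 to compound 4 (beyond the scatter), the first change in one place that can be read in this series. It shows that the read-out is sensitive to what sits at this carbon of the shared core: a single heavy atom, with no ring and no hydrogen-bond donor or acceptor, produces a large step. Nothing measured here explains the rise.

From the compounds shown here alone, whether this step belongs to bromo itself stays open, since an amine or a methoxy group at this carbon could give a smaller step, a similar one or a larger one. Going by these compounds, it is also open whether bromo would bring a comparable step on a compound carrying a different group in place of the nitro-bearing side group of compound 2.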